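Series notes: aryl sulfonylurea chalcones, brine shrimp cytotoxicity

The compounds below may be only part of what the source reports. "The series", "measured", "known", "first", "only" and "open" are said of these compounds alone.

Compound 1 `COc1cccc(/C=C/C(=O)c2ccccc2NC(=O)NS(=O)(=O)c2ccc(C)cc2)c1` gives 23.2 ug/mL in an ADME assay on the whole organism for cytotoxicity, with Artemia salina as the target, with a stated time of 24 h; a lower number here means that less compound is needed, a higher number that more compound is needed for the effect. Compound 2 `Cc1ccc(S(=O)(=O)NC(=O)Nc2ccccc2C(=O)/C=C/c2cccc([N+](=O)[O-])c2)cc1` gives 44.5 ug/mL in this assay. The step of a 1.9-fold higher number from compound 1 to compound 2 (0.28 log units; within the scatter) is the only one measured. Compound 2 has the higher of the two numbers, though within the scatter of compound 1. Compound 3 `Cc1ccc(S(=O)(=O)NC(=O)Nc2ccccc2C(=O)/C=C/c2cccc(F)c2)cc1` differs from compound 2 by fluoro in place of nitro on an aromatic carbon. Going by the values given here, no measured step covers this change; the single related step, methoxy to nitro, stayed within the scatter, so no step beyond the scatter is expected in this assay. Compound 3 is therefore estimated at 35 ug/mL (15 ug/mL to 80 ug/mL). The expected step is a 1.3-fold lower number from compound 2 to compound 3 (0.10 log units; within the scatter).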

Compound 3, concentration for half-maximal effect: 4.13 ug/mL
Estimate against measurement, compound 3: 8.5-fold (0.93 log units) above, outside the stated range (below it).
By their numbers in this assay, from the lowest: compound 3; then compounds 1 and 2 (each within the scatter of the next).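

In this assay the earlier change at this aromatic carbon, meta to a large group, stayed within the scatter, but fluoro gives an 11-fold lower number from compound 2 to compound 3 (1.03 log units; beyond the scatter) and also a 5.6-fold lower number from compound 1 to compound 3 (0.75 log units; beyond the scatter) in the same series. The position therefore does respond to its substituent, with 3-fluorophenyl standing apart from both the nitro and the methoxy compounds. No measured evidence accounts for this difference.

On these data alone, whether the shift is specific to fluoro or extends to chloro, an amine or a plain hydrogen at this carbon remains open. Also open, as far as these compounds go, is whether fluoro elsewhere on this ring behaves the same way.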